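From isopropyl to 3-phenoxypropyl: an expected upward step

A few compounds are considered here, and "the series" means these few. Any claim that something is new, unique, unknown or untested is made for them only; others in the source may bear on it.

Compound 1 `CCCCCCCCN(Cc1ccc(C(=O)NO)cc1)c1ncc(-c2ccc(C)cc2)s1`: 8760 nM
Compound 2 `Cc1ccc(-c2cnc(N(Cc3ccc(C(=O)NO)cc3)C(C)C)s2)cc1`: 2180 nM

In a functional assay on HepG2 cells (Homo sapiens) for antiproliferative activity, read by MTT assay, with a stated time of 48 h (on this read-out higher numbers stand for weaker inhibition of growth and lower numbers for stronger inhibition of growth), compound 2 holds the lower of the two numbers. Compound 3 `Cc1ccc(-c2cnc(N(CCCOc3ccccc3)Cc3ccc(C(=O)NO)cc3)s2)cc1` carries 3-phenoxypropyl in place of isopropyl on a nitrogen on an aromatic ring. Within the data shown here, only one measured step bears on this change: a 4.0-fold lower number from compound 1 to compound 2 (0.60 log units; beyond the scatter), modest and beyond the scatter, with isopropyl in place of octyl. Going back to a larger group may therefore raise the number by a similar modest amount, though no measured compound carries the phenoxy group. The expected change is a 2.1-fold higher number from compound 2 to compound 3 (0.31 log units; beyond the scatter). Compound 3 is estimated at 4500 nM, with an expected range of 1300 nM to 13000 nM.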

Compound 3, concentration for 50% growth inhibition: 23400 nM
Beside the measured number, compound 3's estimate is 5.2-fold (0.72 log units) below it, and the stated range ends below it.
By their numbers in this assay, from the lowest: compound 2; then compound 1; then compound 3.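

In this assay, 3-phenoxypropyl in place of isopropyl on this nitrogen gives an 11-fold higher number from compound 2 to compound 3 (1.03 log units; beyond the scatter) and is a large change, well beyond the modest one seen with octyl. Phenoxy in place of pentyl at the end of the chain gives a 2.7-fold higher number from compound 1 to compound 3 (0.43 log units; beyond the scatter) so, of the three compounds, the phenoxy-ended chain and not the octyl chain holds the highest number. No data here say why the phenoxy end raises the number.
Open, as far as these compounds go, is whether 3-phenylpropyl, without the oxygen, behaves like 3-phenoxypropyl. Also open, from the compounds shown here alone, is where an ethyl group or a chain ending in an amine would fall.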